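Swapping a fluorine for a chlorine on the benzyl arm

A few compounds are considered here, and "the series" means these few. Any claim that something is new, unique, unknown or untested is made for them only; others in the source may bear on it.

Measured so far:
Compound 1, `Nc1nc(NCc2ccccc2)nc(-c2ccccc2CO)n1`: 4.35
Compound 2, `Nc1nc(NCc2ccc(F)cc2)nc(-c2ccccc2CO)n1`: 3.97

Both numbers come from a functional assay on cells for positive allosteric modulation of G-protein coupled receptor 68 (Homo sapiens), read by a luciferase reporter and cAMP accumulation, with a stated time of 30 min, at pH 6.8 and pH 8.3, in the presence of a further agent that is not named here; a lower number here means a less potent compound, a higher number a more potent compound, by a factor of ten per unit of this negative logarithm. Going by the values given here, compound 2 has the lower of the two, its only neighbour being compound 1, with the change from compound 1 to compound 2 being a number 0.38 log units lower from compound 1 to compound 2 (beyond the scatter) for fluoro in place of hydrogen on an aromatic carbon. Compound 3, `Nc1nc(NCc2ccccc2Cl)nc(-c2ccccc2CO)n1`, carries the change (2-chlorophenyl in place of 4-fluorophenyl on a saturated chain carbon bound to a nitrogen on an aromatic ring). Among the compounds with values here, only that one step bears on it: the fluorine that cost potency leaves, and a chlorine arrives elsewhere on the ring, for which no measured step exists. A modest rise is therefore expected for compound 3, a number 0.33 log units higher from compound 2 to compound 3 (beyond the scatter), giving an estimate of 4.3, within 3.7 to 4.9.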

Compound 3, negative logarithm of the antagonist equilibrium constant: 5.07
The estimate for compound 3 lay 0.77 log units below the measured number, outside the stated range (above it).
By their numbers in this assay, from the lowest: compound 2; then compound 1; then compound 3.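

A chlorine on the benzyl arm gives a number 0.72 log units higher from compound 1 to compound 3 (beyond the scatter), so a substituent on this ring can raise the number, whereas the fluorine of compound 2 lowered it. Replacing 4-fluorobenzyl with 2-chlorobenzyl gives a number 1.10 log units higher from compound 2 to compound 3 (beyond the scatter), a large step between two arms of equal heavy-atom count. Nothing available here explains this gain.

The halogen and its place on the ring changed together, so the compounds shown cannot tell which of the two matters. On these data alone, whether a methoxy group in the place of the chlorine would also raise the number remains open.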